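A few compounds are considered here, and "the series" means these few. Any claim that something is new, unique, unknown or untested is made for them only; others in the source may bear on it.

Compound 2 `S=C(Nc1cccnc1)NC1CCN(c2cc(OCc3ccccc3)ccn2)CC1` gives 2800 nM in an assay on membranes from brain for binding affinity to Lysophosphatidylserine lipase ABHD12 (Mus musculus), read by fluorescence, with a stated time of 20 min (on this read-out lower numbers stand for stronger inhibition and higher numbers for weaker inhibition), the highest of the three numbers recorded; compound 1 `FC(F)(F)Oc1ccc(Oc2ccnc(N3CCC(NC(=S)Nc4cccnc4)CC3)c2Cl)cc1` gives 25 nM and compound 3 `FC(F)(F)Oc1ccc(Oc2ccnc(N3CCC(NC(=S)Nc4cccnc4)CC3)c2Cl)c(Cl)c1` gives 11 nM, both carrying an aryloxy group where compound 2 carries benzyloxy, together with a further chloro on the shared core. Compound 4 `COc1ccc(Oc2ccnc(N3CCC(NC(=S)Nc4cccnc4)CC3)c2)cc1` makes the change (4-methoxyphenyl in place of benzyl on an oxygen on an aromatic ring), so that the aryl ring sits directly on the oxygen as in compound 1 and compound 3, but without the chloro on the core. Going by the values given here, the only single-step comparison, a 2.3-fold lower number from compound 1 to compound 3 (0.36 log units; beyond the scatter), concerns an outer-ring substituent and bears on the present change only loosely. The large gap between compound 2 and compound 1 is expected to carry over in part, giving an expected step of a 14-fold lower number from compound 2 to compound 4 (1.15 log units; beyond the scatter). Compound 4 is therefore estimated at 200 nM, within 50 nM to 800 nM.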

Compound 4, half-maximal inhibitory concentration: 2900 nM
For compound 4 the middle estimate is 15-fold (1.16 log units) below the measured one; the whole stated range lies below it.
By their numbers in this assay, from the lowest: compound 3; then compound 1; then compounds 2 and 4 (each within the scatter of the next).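

In this assay the change from benzyloxy to 4-methoxyphenoxy gives a 1.0-fold higher number from compound 2 to compound 4 (0.02 log units; within the scatter) and so, on the shared core without the chloro, the two groups cannot be told apart. Putting an aryl ring directly on the oxygen is therefore not enough on its own to shift the number with this substituent on that ring. Nothing available accounts for this result.

Still open, as far as these compounds go, is how the chloro on the core acts alone with 4-methoxyphenoxy in place. Also open, from the compounds shown here alone, is how an unsubstituted phenoxy or a longer chain such as phenethyloxy would read at this position.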